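The source may hold more compounds than are shown below. What is called first, only, known or untested is meant among the compounds shown, and "the series" means these compounds.

Measured so far:
- compound 1, `Cc1ccc(S(=O)(=O)Oc2ccc3c(c2C)[C@H](Cn2cc(-c4ccccc4)nn2)[C@@]24CC(=O)[C@@](C)(CC[C@@H]32)C4)cc1`, in a functional assay on SW480 cells (Homo sapiens) for cytotoxicity, read by MTT assay, with a stated time of 4 days (a lower number here means a stronger inhibitor, a higher number a weaker inhibitor), compound 1 gives > 20000 nM
- compound 2, `C=C1C[C@]23C[C@@]1(O)CC[C@H]2c1ccc(O)c(C)c1[C@@H]3Cn1cc(-c2ccc(C(F)(F)F)cc2)nn1`, in this assay compound 2 gives > 20000 nM

Both of these values are limits of the assay rather than measured numbers. The value of compound 2 in this assay is a limit. The value of compound 1 in this assay is likewise a limit. Within the data shown here, compound 2 therefore stands where every value shown stands, at the limit of > 20000 nM in this assay, at which 2 of the 2 values shown sit, and no number separates it from compound 1; no step between the two measured compounds can be stated, only that both values are limits.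

Compound 3, `C=C1C[C@]23C[C@@]1(O)CC[C@H]2c1ccc(O)c(C)c1[C@@H]3Cn1cc(-c2ccccc2)nn1`, has not yet been measured in this assay. It differs from compound 2 by hydrogen in place of trifluoromethyl on an aromatic carbon. Among the measured compounds shown here, with compound 2 at the limit and no measured step to draw on, the step from compound 2 to compound 3 is expected to be none beyond the scatter, a step that the limit leaves unreadable from compound 2 to compound 3, with the result most likely again a limit. Compound 3 is estimated to give 30000 nM in this assay, within a range of 8000 nM to 100000 nM.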

Compound 3, half-maximal inhibitory concentration: > 20000 nM
Compound 3: a limit, no number; the forecaster's own chance of this, stated with the estimate: 80%; the middle value is on the limit's open side.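

In this assay compound 3 gives > 20000 nM, which is a limit and not a number. No step can be read from compound 2 to compound 3, as both values are limits: the limit of > 20000 nM in this assay, at which 3 of the 3 values shown sit. The compounds shown leave open whether phenyl and 4-(trifluoromethyl)phenyl differ at all in this assay, and what actual number compound 1, compound 2 or compound 3 would give.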